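Notes on a methyl-to-fluoro exchange across two cores

A few compounds are considered here, and "the series" means these few. Any claim that something is new, unique, unknown or untested is made for them only; others in the source may bear on it.

Measured in a functional assay on HepG2 cells (Homo sapiens) for antiproliferative activity, read by MTT assay, with a stated time of 72 h; a higher number here means a weaker inhibitor, a lower number a stronger inhibitor:
- compound 1 `COc1ncc(-c2ccc3c(c2)N(c2ccc(C)cc2)C(=O)CO3)cc1NS(=O)(=O)c1ccc(F)cc1`: 28300 nM
- compound 2 `COc1ncc(-c2ccc3c(c2)N(c2ccc(F)cc2)C(=O)CO3)cc1NS(=O)(=O)c1ccc(F)cc1`: 36400 nM
- compound 3 `Cc1ccc(N2C(=O)COc3ccc(-c4cccc(NS(=O)(=O)c5ccc(F)cc5)c4)cc32)cc1`: > 40000 nM, a limit of the assay and not a number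

Compound 1 and compound 2 share one core; compound 3 carries another, and the difference between the two cores is not broken down here. The change from compound 1 to compound 2 is fluoro in place of methyl on an aromatic carbon. The step it made in this assay was a 1.3-fold higher number from compound 1 to compound 2 (0.11 log units; within the scatter).

Compound 4 `O=C1COc2ccc(-c3cccc(NS(=O)(=O)c4ccc(F)cc4)c3)cc2N1c1ccc(F)cc1` has not yet been measured in this assay. It stands to compound 3 as compound 2 stands to compound 1: the change is fluoro in place of methyl on an aromatic carbon, at the same place, so it is the same change. Compound 3 sits at the limit of > 40000 nM in this assay, at which 1 of the 3 values shown sits. Because a 1.3-fold higher number from compound 1 to compound 2 (0.11 log units; within the scatter) lay within the scatter, no shift of real size is expected from the same change on the second core; the expected step is a step that the limit leaves unreadable from compound 3 to compound 4. Compound 4 is therefore expected at 48000 nM, estimated between 25000 nM and 100000 nM, with a good chance that only a limit is reported again.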

Compound 4, half-maximal inhibitory concentration: > 40000 nM
Compound 4: no number, only a limit; the forecaster's own chance of this, stated with the estimate: 70%; the middle value does not contradict the limit.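

In this assay, compound 3 and compound 4 both give only a limit of the assay and not a number, so no step can be read between them: the limit of > 40000 nM in this assay, at which 2 of the 4 values shown sit.

The compounds shown leave open whether 4-methylphenyl to 4-fluorophenyl changes activity at all on the core of compound 3, and how far that core differs from the core of compound 1.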